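Thiazole Sulfonamide Following Two Comparators at the Limit

A few compounds are considered here, and "the series" means these few. Any claim that something is new, unique, unknown or untested is made for them only; others in the source may bear on it.

In a functional assay on DLD-1 cells (Homo sapiens) for antiproliferative activity, read by CellTiter-Glo, with a stated time of 72 h (on this read-out lower numbers stand for stronger inhibition and higher numbers for weaker inhibition), compound 1 `Cc1noc(C)c1S(=O)(=O)N1CCC(N2CCC(C)CC2)CC1` gives only a limit, > 5000 nM. Compound 2 `COc1cccc(S(=O)(=O)N2CCC(N3CCC(C)CC3)CC2)c1` likewise gives only a limit in this assay, > 5000 nM. Within the data shown here, the step that the two limits leave unreadable from compound 1 to compound 2 therefore cannot be sized, and the only evidence available is the limit of > 5000 nM in this assay, at which 2 of the 2 values shown sit. Compound 3 `Cc1nc(Cl)sc1S(=O)(=O)N1CCC(N2CCC(C)CC2)CC1` differs from compound 2 by 2-chloro-4-methyl-1,3-thiazol-5-yl in place of 3-methoxyphenyl on a sulfonyl sulfur. Among the measured compounds shown here, no measured step bears readably on this change, so a result at the limit is again expected rather than a step beyond the scatter. The step expected is a step that the limit leaves unreadable from compound 2 to compound 3. Compound 3 is estimated at 10000 nM, between 3000 nM and 50000 nM.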

Compound 3, half-maximal inhibitory concentration: 1.6 nM
Compound 3: middle estimate off by 6300-fold (3.80 log units), on the high side, and the stated range ends above it.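

In this assay, the group on the sulfonyl sulfur proves able to decide the read-out, which the two earlier compounds could not show: the limit of > 5000 nM in this assay, at which 2 of the 3 values shown sit. With the shared core unchanged, 2-chloro-4-methyl-1,3-thiazol-5-yl in place of 3-methoxyphenyl gives an at least 3100-fold lower number from compound 2 to compound 3 (3.49 log units; beyond the scatter), and in place of 3,5-dimethyl-1,2-oxazol-4-yl it gives an at least 3100-fold lower number from compound 1 to compound 3 (3.49 log units; beyond the scatter). The step between the two earlier compounds still cannot be read. From the compounds shown here alone, what stays open is whether the chlorine or the methyl of the thiazole carries the step, and whether a nitrile or an amine in place of the chlorine would keep the number this low.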